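Fluoro for hydrogen across two cores in the series

The compounds below may be only part of what the source reports. "The series", "measured", "known", "first", "only" and "open" are said of these compounds alone.

Compound 1 `O=c1c(C2N=C(c3ccccc3)SS2)coc2ccc(F)cc12` and compound 2 `O=c1c(C2N=C(c3ccccc3)SS2)coc2ccccc12` share one core, while compound 3 `O=c1c(C(=S)Nc2ccccc2)coc2ccccc12` and compound 4 `O=c1c(C(=S)Nc2ccccc2)coc2ccc(F)cc12` share another. The difference between the two cores is not broken down here.

In a functional assay on IMR-32 cells (Homo sapiens) for inhibition, read by sulforhodamine B assay, with a stated time of 48 h (a lower number here means a stronger inhibitor, a higher number a weaker inhibitor), compound 2 gives 16500 nM and compound 1 gives 14600 nM. The step of a 1.1-fold lower number from compound 2 to compound 1 (0.05 log units; within the scatter) corresponds to the change (fluoro in place of hydrogen on an aromatic carbon). In this assay compound 3 gives 95800 nM, the highest of the three measured numbers and beyond the scatter from both compound 2 and compound 1.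

Compound 4 is the unmeasured partner of compound 3. The change from compound 3 to compound 4 is fluoro in place of hydrogen on an aromatic carbon, the same change as from compound 2 to compound 1, with the place described in the same words in both cases. Among the four compounds the change occurs twice, and only one instance has been measured, which is thin support for any expectation.

Because a 1.1-fold lower number from compound 2 to compound 1 (0.05 log units; within the scatter) lies within the scatter, the step expected for compound 4 is a 1.1-fold lower number from compound 3 to compound 4 (0.04 log units; within the scatter). In this assay compound 4 is therefore estimated at 87000 nM. For compound 4 the expected range runs from 45000 nM to 170000 nM. Given how high the number for compound 3 already sits, it is also possible that the measurement of compound 4 returns only a limit rather than a number.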

Compound 4, half-maximal inhibitory concentration: 89800 nM
For compound 4 the middle estimate is 1.0-fold (0.01 log units) below the measured one; low and high end bracket the measured number.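

In this assay the new step is a 1.1-fold lower number from compound 3 to compound 4 (0.03 log units; within the scatter), so fluoro in place of hydrogen on an aromatic carbon gives no step beyond the scatter on the core of compound 3, as on the core of compound 2. The two steps agree, and within these four compounds the change carries from one core to the other without a difference that can be read: the same change on two cores in this assay, a 1.1-fold lower number (0.05 log units; within the scatter) from compound 2 to compound 1 and a 1.1-fold lower number (0.03 log units; within the scatter) from compound 3 to compound 4, 1.1-fold (0.03 log units) apart, within the scatter of two such steps. Among these compounds, this agreement rests on two pairs, one place on the ring and one assay, and both steps are within the scatter, so it shows only that the change is silent on both cores, not that a step of readable size would carry over, nor that the same would hold on a third core or in another assay.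

The compounds shown leave open whether any group at this place on the six-membered aromatic ring of carbon only would give a step beyond the scatter on either core, for instance chloro, methoxy, an amine or a carboxylic acid. They also leave open whether such a step, once present, would have the same size on both cores, which is the test that two silent fluoro pairs cannot provide.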